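Another Amide Substituent Exchange on the Shared Core

The compounds below may be only part of what the source reports. "The series", "measured", "known", "first", "only" and "open" are said of these compounds alone.

Compound 1 `CC(C)(C)c1ccc(C(=O)N2CCC3(CC2)C(=O)N(CC(=O)NCNS(C)(=O)=O)CN3c2ccccc2)cc1`: in an assay on HEK293 cells for displacement of a labelled ligand from NPC1-like intracellular cholesterol transporter 1 (Homo sapiens) (on this read-out lower numbers stand for stronger inhibition and higher numbers for weaker inhibition), compound 1 gives 3200 nM.
Compound 2 `CCOC(=O)C1CCN(C(=O)CN2CN(c3ccccc3)C3(CCN(C(=O)c4ccc(C(C)(C)C)cc4)CC3)C2=O)CC1`: in this assay compound 2 gives 3100 nM.

Compound 2 holds the lowest of the two numbers, but its nearest neighbour, compound 1, sits within the scatter of it, so no order between the two can be claimed. Among the compounds with values here, the one measured step at this position, a 1.0-fold lower number from compound 1 to compound 2 (0.01 log units; within the scatter), shows that swapping the group on the carbonyl carbon left the number essentially where it was.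

Compound 3 `CC(C)(C)c1ccc(C(=O)N2CCC3(CC2)C(=O)N(CC(=O)NCCCCO)CN3c2ccccc2)cc1` differs from compound 2 by (4-hydroxybutyl)amino in place of 4-(ethoxycarbonyl)piperidin-1-yl on a carbonyl carbon. The step bearing on this change is a 1.0-fold lower number from compound 1 to compound 2 (0.01 log units; within the scatter), which was within the scatter; on that basis the new group is expected to produce no step beyond the scatter in this assay either. The estimate for compound 3 is 3000 nM, with a range from 1200 nM to 8000 nM. This amounts to an expected 1.0-fold lower number from compound 2 to compound 3 (0.01 log units; within the scatter).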

Compound 3, half-maximal inhibitory concentration: 19200 nM
For compound 3 the middle estimate is 6.4-fold (0.81 log units) below the measured one, outside the stated range (above it).
By their numbers in this assay, from the lowest: compounds 2 and 1 (each within the scatter of the next); then compound 3.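

Within the data shown here, the group on this carbonyl carbon does matter in this assay: with (4-hydroxybutyl)amino in place of 4-(ethoxycarbonyl)piperidin-1-yl there is a 6.2-fold higher number from compound 2 to compound 3 (0.79 log units; beyond the scatter), the first step here beyond the scatter. The comparison with the other earlier group agrees, with 3-hydroxypropyl in place of methanesulfonamido giving a 6.0-fold higher number from compound 1 to compound 3 (0.78 log units; beyond the scatter), so the position tolerates two quite different groups at nearly the same number but not this hydroxybutyl chain. Nothing measured here accounts for this step.

The compounds shown leave open whether the step goes with the hydroxy group or with an open chain standing where the ring stood. A plain butylamino group, an unsubstituted piperidin-1-yl group or a piperidine bearing a carboxylic acid would bear on that question.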